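Alkyl exchange on the carbonyl carbon: from compound 3 to compound 4

The source may report more compounds than this note shows. Statements on the series, on what has been measured and on what is new or still open speak of the compounds shown alone.

Measured compounds in an ADME assay on HEK293 cells (Homo sapiens) for inhibition, read by MTT assay, with a stated time of 96 h; a higher number here means a weaker inhibitor of growth, a lower number a stronger inhibitor of growth:
Compound 1, `O=C(NCCCCCCSSCCCCCCNC(=O)c1cc(-c2ccncc2)n[nH]1)c1cc(-c2ccncc2)n[nH]1`, gives 14800 nM.
Compound 2, `O=C(OCc1ccccc1)SCCCCCCNC(=O)c1cc(-c2ccncc2)n[nH]1`, gives 19700 nM.
Compound 3, `CC(C)C(=O)SCCCCCCNC(=O)c1cc(-c2ccncc2)n[nH]1`, gives only the assay limit > 50000 nM.

Compound 3 thus stands at the limit of this assay and has no number of its own. Among the measured compounds shown here, the step of an at least 2.5-fold higher number from compound 2 to compound 3 (0.40 log units; beyond the scatter) is the only measured change on the carbonyl carbon whose other neighbour is sulfur, and because compound 3 sits at the limit of > 50000 nM in this assay, at which 1 of the 3 values shown sits, that step is itself known only as a bound. Compound 4, `CCCC(=O)SCCCCCCNC(=O)c1cc(-c2ccncc2)n[nH]1`, differs from compound 3 by propyl in place of isopropyl on a carbonyl carbon. For the measured compounds named here, no measured pair exchanges one short alkyl chain for another, so the one measured step at this position, an exchange of benzyloxy for isopropyl, does not bear directly on the present change. The two compounds have the same atoms, joined differently, and neither group brings a ring, a donor or an acceptor, so no shift beyond the scatter of this assay is expected; the estimated step that the limit leaves unreadable from compound 3 to compound 4 is expected to be flat. Compound 4 is expected to sit at about 60000 nM, within 25000 nM to 150000 nM, and most likely to be returned again only as the limit of this assay.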

Compound 4, concentration for 50% growth inhibition: > 50000 nM
Compound 4: no number, only a limit (the forecaster's own chance of this, stated with the estimate: 70%); the middle value does not contradict the limit.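

In this assay compound 4 gives > 50000 nM, which is a limit of the assay and not a number. Because compound 3 and compound 4 both sit at this limit, the step between them cannot be read, and the exchange of isopropyl for propyl on the carbonyl carbon has no measured size: the limit of > 50000 nM in this assay, at which 2 of the 4 values shown sit. What the new compound adds lies in the comparison with benzyloxy: propyl in place of benzyloxy on the carbonyl carbon whose other neighbour is sulfur gives an at least 2.5-fold higher number from compound 2 to compound 4 (0.40 log units; beyond the scatter), so the step seen with isopropyl in this assay is not tied to isopropyl alone.

From the compounds shown here alone, how far compound 3 and compound 4 would lie from each other without the limit stays open, so no order between them can be given. Also open, going by these compounds, is which part of benzyloxy goes with the lower number in compound 2, a question that a benzyl group without the oxygen, an ethoxy group without the ring, or a longer alkyl chain on the same carbonyl carbon could address.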